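The source may hold more compounds than are shown below. What is called first, only, known or untested is meant among the compounds shown, and "the series" means these compounds.

Measured so far:
- compound 1, `Fc1ccccc1Cn1cc(CSC(=S)N2CCNCC2)nn1`, 33200 nM
- compound 2, `S=C(SCc1cn(Cc2ccc(Cl)c(Cl)c2)nn1)N1CCNCC1`, "not determined" (no result reported)
- compound 3, `O=C(OCc1ccccc1)N1CCN(C(=S)SCc2cn(Cc3ccc(Cl)c(Cl)c3)nn2)CC1`, 10600 nM

The three compounds share a core in which a piperazine ring carries a thiocarbamate linked through sulfur to a triazole, and the triazole in turn carries a benzyl group. In a functional assay on MCF7 cells (Homo sapiens) for inhibition, read by MTT assay, with a stated time of 72 h (on this read-out higher numbers stand for weaker inhibition and lower numbers for stronger inhibition), compound 1 gives 33200 nM. Compound 2 differs from compound 1 in carrying a 3,4-dichlorobenzyl group on the triazole. In this assay compound 2 gives "not determined" (no result reported). Compound 3 adds a benzyl carbamate to the piperazine of compound 2. In this assay compound 3 gives 10600 nM, which is the lower of the two numbers recorded; its gap to compound 1 lies beyond the usual scatter of this kind of measurement.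

Compound 4, `Cc1ccc(Cn2cc(CSC(=S)N3CCN(C(=O)OCc4ccccc4)CC3)nn2)cc1`, is the next step from compound 3. The change is 4-methylphenyl in place of 3,4-dichlorophenyl on a saturated chain carbon bound to an aromatic nitrogen. Going by the values given here, no measured pair in this set shows what this exchange does, so the expectation rests on compound 3 alone. A modest weakening is expected, with the step from compound 3 to compound 4 estimated as a 1.7-fold higher number from compound 3 to compound 4 (0.23 log units; within the scatter), a size not far outside the scatter. Compound 4 is therefore expected to give about 18000 nM in this assay, with a likely range from 7000 nM to 45000 nM.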

Compound 4, half-maximal inhibitory concentration: 37800 nM
The estimate for compound 4 lay 2.1-fold (0.32 log units) below the measured number; low and high end bracket the measured number.
By their numbers in this assay, from the lowest: compound 3; then compounds 1 and 4 (each within the scatter of the next).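

Going by these compounds alone, the exchange of 3,4-dichlorophenyl for 4-methylphenyl on a saturated chain carbon bound to an aromatic nitrogen provides the first comparison in this set that differs in only one place, and in this assay it reads a 3.6-fold higher number from compound 3 to compound 4 (0.55 log units; beyond the scatter). This shows that the group at this position matters to the read-out: with the rest of the molecule unchanged, the two groups lie beyond the usual scatter of each other, and 3,4-dichlorophenyl gives the stronger inhibition of the pair. No measurement available here explains this difference, so the step records only the size and direction of the change, not its origin.

As far as these compounds go, this single exchange removes two chlorine atoms and adds one methyl group at the same time, so it remains open how much each part contributes; plain phenyl or 4-chlorophenyl at this position would separate those parts. A carboxylic acid or an amine on the ring would also test whether groups of a very different kind are accepted at this position.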